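A methoxy added to the phenyl on nitrogen

The source may hold more compounds than are shown below. What is called first, only, known or untested is meant among the compounds shown, and "the series" means these compounds.

Compound 1 `C=CC/N=C1\S/C(=C\c2ccc(OC)cc2)C(=O)N1C`: 79300 nM
Compound 2 `COc1ccc(/C=C2\S/C(=N\c3ccccc3)N(C)C2=O)cc1`: > 100000 nM, a limit of the assay

Both values come from a functional assay on HCT-116 cells (Homo sapiens) for antiproliferative activity, read by MTT assay, with a stated time of 72 h; a lower number here means a stronger inhibitor, a higher number a weaker inhibitor. Compound 2 stands at the limit of > 100000 nM in this assay, at which 1 of the 2 values shown sits, so it has a limit and no number. Compound 3 `COc1ccc(/C=C2\S/C(=N\c3ccc(OC)cc3)N(C)C2=O)cc1` follows from compound 2 by methoxy in place of hydrogen on an aromatic carbon, para to a large group, which turns phenyl to 4-methoxyphenyl. Among the compounds with values here, the one measured step, an at least 1.2-fold higher number from compound 1 to compound 2 (0.10 log units; that floor lies within the scatter), replaces allyl with phenyl on a double-bonded nitrogen, and its floor lies within the scatter. Within the data shown here, no measured pair carries the methoxy change itself. No step beyond the scatter is therefore expected in this assay, in either direction. The estimated change is a number no higher from compound 2 to compound 3 (the limit leaves the size open). Compound 3 is expected at 100000 nM, with an estimated range of 40000 nM to 250000 nM.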

Compound 3, half-maximal inhibitory concentration: > 100000 nM
Compound 3: no number, only a limit; the forecaster's own chance of this, stated with the estimate: 55%; the middle value lies on the limit itself.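

In this assay compound 3 gives > 100000 nM, which is a limit of the assay and not a number. Methoxy on this aromatic carbon, para to a large group, thus leaves compound 3 at the same limit as compound 2, and the step between them cannot be read, since neither end of it is a number: the limit of > 100000 nM in this assay, at which 2 of the 3 values shown sit. Measured against the allyl group on the double-bonded nitrogen, 4-methoxyphenyl gives an at least 1.2-fold higher number from compound 1 to compound 3 (0.10 log units; that floor lies within the scatter), so this comparison also establishes no step beyond the scatter.

Going by these compounds, how far compound 2 and compound 3 lie past the limit stays open, and with it whether methoxy has any effect here at all. Also open, on these data alone, is how an amine or a carboxylic acid in the same place would read in this assay.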